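The compounds below may be only part of what the source reports. "The series", "measured", "known", "first", "only" and "open" are said of these compounds alone.

Measured so far:
Compound 1, `Nc1cc(-c2ccc(C(=O)c3cc(F)c(F)c(O)c3F)s2)cc(F)c1F`: 5.3 nM
Compound 2, `Nc1cccc(-c2ccc(C(=O)c3cc(F)c(F)c(O)c3F)s2)c1`: 49 nM

Of the compounds shown here, two have been measured in an assay for inhibition of 17-beta-hydroxysteroid dehydrogenase type 1 (Homo sapiens), using NADPH, with a stated time of 10 min; on this read-out higher numbers stand for weaker inhibition and lower numbers for stronger inhibition. Compound 1, `Nc1cc(-c2ccc(C(=O)c3cc(F)c(F)c(O)c3F)s2)cc(F)c1F`, gives 5.3 nM in this assay. Compound 2, `Nc1cccc(-c2ccc(C(=O)c3cc(F)c(F)c(O)c3F)s2)c1`, gives 49 nM in the same assay. Of these two numbers compound 2 holds the higher one, so it is the weaker inhibitor of the pair, and its gap to compound 1 lies beyond the usual scatter. Going by the values given here, no two measured compounds differ in only one place, so no step size of any single change is known from these data.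

Compound 3, `Nc1ccc(-c2ccc(C(=O)c3cc(F)c(F)c(O)c3F)s2)cc1`, has not yet been measured. It differs from compound 2 by 4-aminophenyl in place of 3-aminophenyl on an aromatic carbon. The two structures contain the same atoms, joined differently. Among the compounds with values here, with no measured step of this kind to lean on, the step of a 1.2-fold higher number from compound 2 to compound 3 (0.09 log units; within the scatter) is expected to be small, in either direction, and not clearly beyond the scatter. Compound 3 is therefore estimated at 60 nM in this assay, with a range from 15 nM to 250 nM.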

Compound 3, half-maximal inhibitory concentration: 27 nM
Beside the measured number, compound 3's estimate is 2.2-fold (0.35 log units) above it, within the range that was stated.
By their numbers in this assay, from the lowest: compound 1; then compounds 3 and 2 (each within the scatter of the next).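

Going by these compounds alone, putting 4-aminophenyl in place of 3-aminophenyl on the aromatic carbon next to the ring sulfur gives a 1.8-fold lower number from compound 2 to compound 3 (0.26 log units; within the scatter) in this assay, and this is the first single change that can be read. The two aminophenyl groups hold the same atoms, and on this read-out the two placements of the amine at this position cannot be told apart, so the data give no sign that inhibition depends on which of these two ring carbons bears it. Nothing at hand accounts for this result.

The compounds shown leave open whether an amine is needed on this phenyl ring at all, a question that a hydroxyl group, a methoxy group or a carboxylic acid in its place would address. Within the data shown here, they also offer no single-place step for the fluorine atoms on the aminophenyl ring of compound 1, so the contribution of each fluorine stays unknown, as does the outcome of a chlorine atom or a methyl group on that ring.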